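The compounds below may be only part of what the source reports. "The series", "measured", "known", "first", "only" and "open" are said of these compounds alone.

Measured compounds:
- compound 1, `CO[C@H]1CC[C@@H](Nc2cc(NCc3cnccc3C(F)(F)F)ncc2C#N)CC1`: 58 nM
- compound 2, `N#Cc1cnc(NCc2ccccc2C(F)(F)F)cc1N[C@H]1C[C@H](C(N)=O)C1`: 5000 nM

In an assay on isolated protein for inhibition of protein kinase C theta type (Homo sapiens), read by TR-FRET, with a stated time of 2 h (a lower number here means a stronger inhibitor, a higher number a weaker inhibitor), compound 1 gives the lowest number of the two shown, and compound 2 gives a number far higher, a gap beyond the scatter of repeated runs. Compound 2 differs from compound 1 in more than one part of the molecule, so on its own it does not show what any single change does.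

Compound 3, `N#Cc1cnc(NCc2cnccc2C(F)(F)F)cc1N[C@H]1CC[C@@H](C(N)=O)CC1`, has not yet been measured. It keeps the core and the pyridine-bearing side of compound 1 and changes one position: carbamoyl in place of methoxy on a saturated ring carbon. Because compound 1 gives 58 nM and no single-change comparison involving a carbamoyl group is available, the expectation for compound 3 rests on compound 1 alone. A step of modest size toward a higher number, possibly within the scatter, is expected for compound 3, a 2.6-fold higher number from compound 1 to compound 3 (0.41 log units; beyond the scatter). Compound 3 is therefore estimated at 150 nM, with a range from 40 nM to 600 nM.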

Compound 3, half-maximal inhibitory concentration: 7 nM
Estimate against measurement, compound 3: 21-fold (1.33 log units) above; measured number outside the range, below it.
By their numbers in this assay, from the lowest: compound 3; then compound 1; then compound 2.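

In this assay, carbamoyl in place of methoxy on this saturated ring carbon gives an 8.3-fold lower number from compound 1 to compound 3 (0.92 log units; beyond the scatter), the only single-place comparison among the compounds shown. It shows that this carbon of the six-membered ring, three ring bonds from the ring atom that bears a large group, is sensitive to what sits on it, and that carbamoyl, with 1 hydrogen-bond donor where methoxy has 0, is well accepted there. No measurement here explains the lower number, so its cause remains unknown.

As far as these compounds go, whether an amine, a carboxylic acid or a longer chain on the same carbon would also lower the number remains open. So does whether carbamoyl would give a similar step with a different group elsewhere on the shared core.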